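Fluoro for Methyl: What to Expect for Compound 3

The compounds below may be only part of what the source reports. "The series", "measured", "known", "first", "only" and "open" are said of these compounds alone.

Of the compounds shown here, two have been measured in a functional assay on SGC-7901 cells (Homo sapiens) for antiproliferative activity, read by MTT assay, with a stated time of 24 h; on this read-out higher numbers stand for weaker inhibition and lower numbers for stronger inhibition. Compound 1 `O=C(NNc1cccc(Cl)c1)c1ccccc1NS(=O)(=O)c1cnc(O)nc1O` gives 10800 nM, and compound 2 `Cc1ccc(C(=O)NNC(=O)c2ccccc2NS(=O)(=O)c2cnc(O)nc2O)cc1` gives 15500 nM; after the step of a 1.4-fold higher number from compound 1 to compound 2 (0.16 log units; within the scatter), compound 2 stands highest of the two numbers, a difference within the scatter. Compound 3 `O=C(NNC(=O)c1ccccc1NS(=O)(=O)c1cnc(O)nc1O)c1ccc(F)cc1` differs from compound 2 by fluoro in place of methyl on an aromatic carbon. Going by the values given here, no measured step bears directly on this change; the single step known alters a different part of the molecule and itself lies within the scatter. Compound 3 is therefore expected to show a step of a 1.0-fold lower number from compound 2 to compound 3 (0.01 log units; within the scatter) no larger than the scatter, with an estimated 15000 nM in this assay and a range from 7000 nM to 32000 nM.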

Compound 3, half-maximal inhibitory concentration: > 20000 nM
Compound 3: no number, only a limit; the forecaster's own chance of this, stated with the estimate: 5%; middle value at least 1.3-fold (0.12 log units) away from the limit.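

In this assay compound 3 gives a limit and not a number: the limit of > 20000 nM in this assay, at which 1 of the 3 values shown sits. Fluoro in place of methyl on this aromatic carbon gives an at least 1.2-fold higher number from compound 2 to compound 3 (0.11 log units; that floor lies within the scatter), while the change from compound 1 gives an at least 1.8-fold higher number from compound 1 to compound 3 (0.26 log units; that floor lies within the scatter); each floor lies within the scatter. Going by these compounds alone, the new result therefore shows that this change at this position brought no lower number, something the earlier compounds could not show, but it does not fix the size of either step.

Going by these compounds, it remains open how large these steps really are, and whether an amine or a methoxy group in this place would lower the number.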